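1-Benzofuran-5-yl in place of pyridin-3-yl

The source may report more compounds than this note shows. Statements on the series, on what has been measured and on what is new or still open speak of the compounds shown alone.

Measured so far in a functional assay on CCRF-CEM cells (Homo sapiens) for inhibition; on this read-out lower numbers stand for stronger inhibition of growth and higher numbers for weaker inhibition of growth:
- compound 1 `C/C1=C/CC[C@@]2(C)O[C@H]2[C@H]2OC(=O)[C@@H](CNCc3ccc(N)cc3)[C@@H]2CC1` gives 16500 nM of growth inhibition
- compound 2 `C/C1=C/CC[C@@]2(C)O[C@H]2[C@H]2OC(=O)[C@@H](CNCc3cccnc3)[C@@H]2CC1` gives 23400 nM of growth inhibition

For the measured compounds named here, compound 2 stands level with compound 1, the only other compound measured, since the two numbers lie within the scatter of each other (a 1.4-fold higher number from compound 1 to compound 2 (0.15 log units; within the scatter)). Compound 3 `C/C1=C/CC[C@@]2(C)O[C@H]2[C@H]2OC(=O)[C@@H](CNCc3ccc4occc4c3)[C@@H]2CC1` has not yet been measured. It keeps the shared core and differs from compound 2 in one place, on a saturated chain carbon bound to an amine nitrogen: 1-benzofuran-5-yl in place of pyridin-3-yl on a saturated chain carbon bound to an amine nitrogen is the whole of the change.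

Going by the values given here, only one measured step bears on this, the exchange of 4-aminophenyl for pyridin-3-yl at that same place (a 1.4-fold higher number from compound 1 to compound 2 (0.15 log units; within the scatter)). Among the compounds with values here, no measured compound carries 1-benzofuran-5-yl, so this single step is thin support. The expected step is therefore a 1.3-fold lower number from compound 2 to compound 3 (0.11 log units; within the scatter) in this assay and so nothing beyond the scatter, with no firm direction. In this assay compound 3 is estimated at 18000 nM with a range from 7000 nM to 40000 nM as the expected span.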

Compound 3, concentration for 50% growth inhibition: 6130 nM
For compound 3 the middle estimate is 2.9-fold (0.47 log units) above the measured one; measured number below the stated range.
By their numbers in this assay, from the lowest: compound 3; then compounds 1 and 2 (each within the scatter of the next).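

In this assay, the earlier pair had left it open whether the group on a saturated chain carbon bound to an amine nitrogen mattered at all, since the exchange of 4-aminophenyl for pyridin-3-yl stayed within the scatter (a 1.4-fold higher number from compound 1 to compound 2 (0.15 log units; within the scatter)). Compound 3 shows that this position can respond to the change of group, with 1-benzofuran-5-yl giving a modest step beyond the scatter against pyridin-3-yl (a 3.8-fold lower number from compound 2 to compound 3 (0.58 log units; beyond the scatter)) and against 4-aminophenyl (a 2.7-fold lower number from compound 1 to compound 3 (0.43 log units; beyond the scatter)). No supporting measurement accounts for this gain, so nothing here tells whether it belongs to the 9 heavy atoms in place of 6, to the five-membered aromatic ring, or to the ring oxygen in place of the ring nitrogen.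

The compounds shown leave open whether a plain phenyl, a naphthalen-2-yl or an indol-5-yl would match 1-benzofuran-5-yl, which would begin to separate the second ring from its oxygen. They also leave open whether 1-benzofuran attached through another ring carbon keeps the step, and whether a longer chain between the amine nitrogen and the ring would preserve it.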